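A few compounds are considered here, and "the series" means these few. Any claim that something is new, unique, unknown or untested is made for them only; others in the source may bear on it.

Measured so far in a functional assay on DLD-1 cells (Homo sapiens) for antiproliferative activity, read by CellTiter-Glo, with a stated time of 72 h; on this read-out lower numbers stand for stronger inhibition and higher numbers for weaker inhibition:
compound 1 `CC1CCN(C2CCN(S(=O)(=O)c3nccn3C)CC2)CC1` gives > 5000 nM, a limit of the assay rather than a number.
compound 2 `CC1CCN(C2CCN(S(=O)(=O)c3cncc(Br)c3)CC2)CC1` gives > 5000 nM, likewise a limit.
compound 3 `CC1CCN(C2CCN(S(=O)(=O)c3cccnc3F)CC2)CC1` gives > 5000 nM, again a limit.

Among the measured compounds shown here, compound 3 therefore stands where every value so far stands, at the limit of > 5000 nM in this assay, at which 3 of the 3 values shown sit, so no number places it against the others. Compound 4 `CC1CCN(C2CCN(S(=O)(=O)c3ccccc3Br)CC2)CC1` differs from it by 2-bromophenyl in place of 2-fluoropyridin-3-yl on a sulfonyl sulfur. Three measured steps change the same group on the sulfonyl sulfur, a step that the two limits leave unreadable from compound 1 to compound 2, a step that the two limits leave unreadable from compound 1 to compound 3 and a step that the two limits leave unreadable from compound 2 to compound 3, but all three run between limits and their sizes cannot be read. No direction can be taken from them. Compound 4 is expected to give about 8000 nM, between 2500 nM and 30000 nM, most likely reported again as a limit. This estimate amounts to a step that the limit leaves unreadable from compound 3 to compound 4.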

Compound 4, half-maximal inhibitory concentration: 3 nM
Compound 4: the middle estimate sits 2700-fold (3.43 log units) above what was measured; measured number below the stated range.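

In this assay, the group on the sulfonyl sulfur can decide activity on the shared core: 2-bromophenyl gives an at least 1600-fold lower number from compound 3 to compound 4 (3.22 log units; beyond the scatter), an at least 1600-fold lower number from compound 2 to compound 4 (3.22 log units; beyond the scatter) and an at least 1600-fold lower number from compound 1 to compound 4 (3.22 log units; beyond the scatter). The steps among compound 1, compound 2 and compound 3 cannot be read. The true size of the three new steps stays unknown because each starts from a limit: the limit of > 5000 nM in this assay, at which 3 of the 4 values shown sit.

Compound 4 differs from compound 3 in both its bromine and its carbon-only ring, and the compounds shown do not separate the two. Going by these compounds, whether phenyl or 2-chlorophenyl on the sulfonyl sulfur would keep this activity remains open.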